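Nitro for methoxy: from compound 3 to compound 4

The compounds below may be only part of what the source reports. "The series", "measured", "known", "first", "only" and "open" are said of these compounds alone.

Among the three compounds measured so far, compound 3 `COc1ccccc1C1SCC(=O)N1CCN1CCCCC1` stands lowest in an ADME assay on Vero cells (Chlorocebus sabaeus) for cytotoxicity, read by neutral red uptake, tested at 197 ug/mL (on this read-out higher numbers stand for a weaker effect at the one concentration tested and lower numbers for a stronger effect), at 72%. Its nearest neighbour is compound 2 `O=C1CSC(c2ccc(O)cc2)N1CCN1CCCCC1`, which gives 87% in this assay, and the furthest is compound 1 `O=C1CSC(c2cccc(O)c2)N1CCN1CCCCC1`, which gives 100%; both gaps lie beyond the scatter. Going by the values given here, the only step between measured compounds that differ in one place is a number 13 percentage points lower from compound 1 to compound 2 (beyond the scatter), and it concerns the position of a hydroxy group on the aromatic ring, not an exchange of one group for another.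

The change now considered is nitro in place of methoxy on an aromatic carbon, giving compound 4 `O=C1CSC(c2ccccc2[N+](=O)[O-])N1CCN1CCCCC1`. Among the compounds with values here, no measured step bears directly on a nitro group entering where a methoxy group leaves, so the measured data offer no direction for it, and the step from compound 3 is expected to stay within the scatter, no change at the digits printed from compound 3 to compound 4 (within the scatter). Compound 4 is therefore estimated to give about 72% in this assay, with a range from 50% to 95%.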

Compound 4, a percentage reported as activity, at one concentration (the size of the read-out at that concentration, not a potency): 100%
Estimate against measurement, compound 4: 28 percentage points below; the whole stated range lies below it.
By their numbers in this assay, from the lowest: compound 3; then compound 2; then compounds 1 and 4 (each within the scatter of the next).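

In this assay, nitro in place of methoxy on this aromatic carbon, ortho to a large group, gives a number 28 percentage points higher from compound 3 to compound 4 (beyond the scatter) and so a weaker effect at the one concentration tested. Going by these compounds alone, the earlier step concerned only where a hydroxy group sat, so this is the first sign that exchanging the group itself at this place can move the read-out beyond the scatter. No measured evidence here accounts for this step.

The compounds shown leave open whether the step belongs to the entering nitro group or to the departing methoxy group, a question that an amine or a carboxylic acid on the same carbon would help to settle. They also leave open whether the same exchange elsewhere on the ring would give a step of similar size.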